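The source may hold more compounds than are shown below. What is called first, only, known or untested is meant among the compounds shown, and "the series" means these compounds.

Of the compounds shown here, three in a shared series have been tested in a functional assay on MCF7 cells (Homo sapiens) for inhibition, read by MTT assay, with a stated time of 72 h; a lower number here means a stronger inhibitor, a higher number a weaker inhibitor. Compound 1 `CN(C(=O)NC(=O)c1ccc([N+](=O)[O-])cc1)c1nc(C(F)(F)F)c(C(=O)N/N=C/c2cccc(C(F)(F)F)c2)s1` gives 4.39 ug/mL. Compound 2 `CN(C(=O)NC(=O)c1c(F)cccc1F)c1nc(C(F)(F)F)c(C(=O)N/N=C/c2cc(C(F)(F)F)cc(C(F)(F)F)c2)s1` gives 6.85 ug/mL. Compound 3 `CN(C(=O)NC(=O)c1c(F)cccc1F)c1nc(C(F)(F)F)c(C(=O)N/N=C/c2ccc(C(F)(F)F)cc2)s1` gives 35.3 ug/mL, the highest of the three numbers; its gap to compound 2 and its wider gap to compound 1 both lie beyond the usual scatter, so compound 3 is the weakest inhibitor of the three in this assay .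

Compound 4 `CN(C(=O)NC(=O)c1c(F)cccc1F)c1nc(C(F)(F)F)c(C(=O)N/N=C/c2cccc(C(F)(F)F)c2)s1` has not yet been measured in this assay . It shares all its atoms with compound 3, joined differently: 3-(trifluoromethyl)phenyl in place of 4-(trifluoromethyl)phenyl on a carbon with a double bond to nitrogen. For the measured compounds named here, no pair of measured compounds differs in exactly this way, so the size of the step is not known from a direct comparison. Compound 1, which carries the same 3-(trifluoromethyl)phenyl group, gives a lower number than compound 3, but it also differs elsewhere, so that pair shows only what its two values show.

Compound 4 is expected to give a lower number than compound 3, with an estimated step of a 3.2-fold lower number from compound 3 to compound 4 (0.51 log units; beyond the scatter) in this assay . The estimate for compound 4 in this assay is 11 ug/mL, within a range from 4 ug/mL to 30 ug/mL.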

Compound 4, half-maximal inhibitory concentration: 21.8 ug/mL
For compound 4 the middle estimate is 2.0-fold (0.30 log units) below the measured one; the measured number falls inside the stated range.
By their numbers in this assay, from the lowest: compounds 1 and 2 (each within the scatter of the next); then compounds 4 and 3 (each within the scatter of the next).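

In this assay, 3-(trifluoromethyl)phenyl in place of 4-(trifluoromethyl)phenyl on the carbon with a double bond to nitrogen gives a 1.6-fold lower number from compound 3 to compound 4 (0.21 log units; within the scatter), so these two forms of the group cannot be told apart here. The other two single changes do register: hydrogen in place of one trifluoromethyl on an aromatic carbon gives a 3.2-fold higher number from compound 2 to compound 4 (0.50 log units; beyond the scatter), and 2,6-difluorophenyl in place of 4-nitrophenyl on the carbonyl carbon gives a 5.0-fold higher number from compound 1 to compound 4 (0.70 log units; beyond the scatter). Nothing at hand accounts for any of these steps.

The compounds shown leave open whether the difference between 4-nitrophenyl and 2,6-difluorophenyl holds when the other aromatic group changes. They also leave open how a methoxy group or a chlorine atom would compare with trifluoromethyl on that phenyl ring.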